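The source may hold more compounds than are shown below. What is called first, only, known or untested is meant among the compounds shown, and "the series" means these compounds.

Measured so far in a functional assay on U2OS cells (Homo sapiens) for antiproliferative activity, read by MTT assay, with a stated time of 72 h; on this read-out lower numbers stand for stronger inhibition and higher numbers for weaker inhibition:

Compound 2 `O=C(CSc1ncc[nH]1)Nc1ccc2nc(NC(=O)c3ccc(C(F)(F)F)cc3)sc2c1`: 18800 nM
Compound 3 `Cc1ccc(C(=O)Nc2nc3ccc(NC(=O)CSc4ccc(Cl)cc4)cc3s2)cc1`: 3190 nM
Compound 1 `O=C(Cc1nnc(NC(=O)c2ccc(Cl)cc2)s1)N/N=C/c1ccc(O)cc1`: > 100000 nM, which is a limit of the assay and not a number; see (the limit of > 100000 nM in this assay, at which 1 of the 3 values shown sits).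

Of the two numbers, compound 2 gives the higher one; compound 3 gives a lower number, and the gap between the two lies beyond the scatter. For the measured compounds named here, no pair differing in a single place has been measured, so no step is yet known for this series.

Compound 4 `O=C(CSc1cccc(O)c1)Nc1ccc2nc(NC(=O)c3ccc(C(F)(F)F)cc3)sc2c1` is not yet measured. It differs from compound 2 in one place: 3-hydroxyphenyl in place of 1H-imidazol-2-yl on a sulfur. A step from compound 2 to compound 4 is expected to lower the number by a 3.1-fold lower number from compound 2 to compound 4 (0.50 log units; beyond the scatter), a modest drop that rests only on compound 3 giving 3190 nM with its own thioether. For compound 4 the estimate is 6000 nM, within 1500 nM to 25000 nM.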

Compound 4, half-maximal inhibitory concentration: 630 nM
Compound 4: the middle estimate sits 9.5-fold (0.98 log units) above what was measured; the measured number lies below the stated range.
By their numbers in this assay, from the lowest: compound 4; then compound 3; then compound 2. At a limit, above all of these: compound 1.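

In this assay, the group on the sulfur is a sensitive position: a 30-fold lower number from compound 2 to compound 4 (1.47 log units; beyond the scatter), the first single-place change read in this series. The two groups carry the same hydrogen-bond donor and acceptor counts, so those counts alone do not track the step. No measured property at hand bears on this step.

Still open, going by these compounds, is whether the gain belongs to the carbon-only ring or to its hydroxyl. A plain phenyl or a 3-aminophenyl on the same sulfur would separate the two.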